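The compounds below may be only part of what the source reports. "The series", "measured", "known", "first", "only" and "open" are said of these compounds alone.

Measured compounds:
Compound 1 `COc1ccc(/C=C/C2CC=CC(=O)N2)cc1` gives 787 uM in a functional assay on OVCAR-3 cells (Homo sapiens) for inhibition, read by sulforhodamine B assay, with a stated time of 48 h; on this read-out higher numbers stand for weaker inhibition of growth and lower numbers for stronger inhibition of growth.
Compound 2 `COc1ccc(/C=C/C2CC=CC(=O)N2)c(OC)c1` gives only a limit of the assay, > 964 uM, in this assay.

Compound 2 therefore stands at the top of the numbers shown: it sits at the limit of > 964 uM in this assay, at which 1 of the 2 values shown sits, and no number for it is known. Among the compounds with values here, the single measured step, an at least 1.2-fold higher number from compound 1 to compound 2 (0.08 log units; that floor lies within the scatter), is the only one that bears on the next change, since it is the same kind of change; its floor lies within the scatter, so it tells no direction with confidence.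

Compound 3 `COc1cc(OC)c(OC)cc1/C=C/C1CC=CC(=O)N1` differs from compound 2 by methoxy in place of hydrogen on an aromatic carbon. The analogous step from compound 1 to compound 2 gave no clear movement, so for compound 3 no step beyond the scatter is expected in this assay in either direction; the most likely outcome is that compound 3 again returns only a limit rather than a number. Compound 3 is accordingly estimated at 1200 uM, within 600 uM to 3000 uM. This estimate means an expected step that the limit leaves unreadable from compound 2 to compound 3.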

Compound 3, concentration for growth inhibition (reported as GI): > 864 uM
Compound 3 ended at the assay's limit (the forecaster's own chance of this, stated with the estimate: 75%); the middle value does not contradict the limit.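

In this assay compound 3 gives > 864 uM, which is a limit of the assay and not a number. Compound 2 likewise gives a limit, > 964 uM. Within the data shown here, no step can therefore be read between compound 2 and compound 3. The compounds shown leave open whether the further methoxy in compound 3 changes growth inhibition at all.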